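Dienone series: swapping the aryl end for a furan

The source may hold more compounds than are shown below. What is called first, only, known or untested is meant among the compounds shown, and "the series" means these compounds.

Two dienones built on the same core have numbers in a functional assay on Hep cells (Homo sapiens) for cytotoxicity, read by sulforhodamine B assay, with a stated time of 48 h (a higher number here means a weaker inhibitor, a lower number a stronger inhibitor), so far. Compound 1, `CC1=C(/C=C/C(=O)/C=C/c2ccc(Br)cc2)C(C)(C)CCC1`, gives 34500 nM in this assay, the lowest of the two numbers; compound 2, `COc1ccc(/C=C/C(=O)/C=C/C2=C(C)CCCC2(C)C)cc1OC`, gives 72400 nM in this assay, a gap that lies beyond the scatter. Both stand in a weak range.

Compound 3, `CC1=C(/C=C/C(=O)/C=C/c2ccoc2)C(C)(C)CCC1`, is not yet measured. It differs from compound 1 in one place: furan-3-yl in place of 4-bromophenyl on a double-bonded chain carbon bound to a double-bonded chain carbon. Within the data shown here, no measured pair differs in only one place, so there is no comparable step to lean on; the expectation rests on compound 1 alone, whose 34500 nM already sits far from the potent end.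

The step is expected to be small, most likely toward a somewhat higher number, and may well fall within the scatter: a 1.3-fold higher number from compound 1 to compound 3 (0.12 log units; within the scatter). Compound 3 is therefore estimated at 45000 nM in this assay, with a range from 15000 nM to 130000 nM.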

Compound 3, half-maximal inhibitory concentration: > 100000 nM
Compound 3: only a limit was reported; the forecaster's own chance of this, stated with the estimate: 15%; middle value at least 2.2-fold (0.34 log units) from the limit.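

Compound 3 gives > 100000 nM in this assay, which is a limit of the assay and not a number. Furan-3-yl in place of 4-bromophenyl on a double-bonded chain carbon bound to a double-bonded chain carbon gives an at least 2.8-fold higher number from compound 1 to compound 3 (0.46 log units; beyond the scatter), the first one-place step in the series, and it shows that this position does not tolerate every aromatic ring equally in this assay. The true size of the step stays unknown, and only its minimum can be read: the limit of > 100000 nM in this assay, at which 1 of the 3 values shown sits.

The change swaps the ring and removes the bromine together, so the compounds shown cannot separate the two. A plain phenyl or a 4-chlorophenyl at this place would bear on that question, and a thiophen-3-yl would bear on the five-membered ring.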